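Working notes: pentan-3-yl in place of 4-fluorophenoxy

The source may hold more compounds than are shown below. What is called first, only, known or untested is meant among the compounds shown, and "the series" means these compounds.

Values in a physicochemical assay for acid dissociation, for the three measured compounds:
compound 1 `COc1cccc(CNCCCNc2ccnc3cc(Oc4ccc(Cl)cc4)ccc23)c1O`: 9.28
compound 2 `COc1cccc(CNCCCNc2ccnc3cc(Oc4ccc(F)cc4)ccc23)c1O`: 9.28
compound 3 `Fc1ccc(Oc2ccc3c(NCCCNCc4ccco4)ccnc3c2)cc1`: 9.28

Compound 2 stands level with compounds 1 and 3 at the digits shown; its nearest neighbour is compound 1 and its furthest is compound 3, and neither gap exceeds the scatter. The two measured steps read no change at the digits printed from compound 1 to compound 2 (within the scatter) and no change at the digits printed from compound 2 to compound 3 (within the scatter). One exchanges the halogen on an aromatic carbon, the other exchanges the group on the saturated chain carbon bound to an amine nitrogen, and in this assay both leave the value unmoved.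

Compound 4 `CCC(CC)c1ccc2c(NCCCNCc3cccc(OC)c3O)ccnc2c1` has not yet been measured. Relative to compound 2 the difference is pentan-3-yl in place of 4-fluorophenoxy on an aromatic carbon. Both measured steps bear on it only loosely, as neither involves a change of this kind on the fused system, yet both show the value of this series unmoved by substitution at the aryl ether and at the chain end. The step from compound 2 to compound 4 is therefore expected to be a number 0.02 log units higher from compound 2 to compound 4 (within the scatter), none beyond the scatter. For compound 4 the estimate is 9.3, with a range from 8.9 to 9.7.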

Compound 4, acid dissociation constant: 9.47
Beside the measured number, compound 4's estimate is 0.17 log units below it; the measured number falls inside the stated range.
By their numbers in this assay, from the lowest: compounds 1, 2, 3 and 4 (each within the scatter of the next).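

In this assay, within the data shown here, the exchange of the whole 4-fluorophenoxy group for pentan-3-yl on the aromatic carbon of the core reads a number 0.19 log units higher from compound 2 to compound 4 (within the scatter) and so, unlike the earlier steps, it tests this position itself and removes the aryl ether with its ring, without a step beyond the scatter. The reading against the chlorinated partner is a number 0.19 log units higher from compound 1 to compound 4 (within the scatter) and so does not depend on which halogen the departing group carried. Nothing measured here accounts for these readings.

Open, from the compounds shown here alone, is whether a carboxylic acid or a dimethylamino group on this same carbon would give a step beyond the scatter. Also open, going by these compounds, is whether pentan-3-yl reads the same alongside the furan-2-yl chain end of compound 3.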